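Carbamate in Place of Hydroxyl on a Shared Core

The source may hold more compounds than are shown below. What is called first, only, known or untested is meant among the compounds shown, and "the series" means these compounds.

Measured compounds:
compound 1 `CCOCC1=CS(=O)(=O)c2ccccc2C1=O` — 92.4%
compound 2 `CC(=O)OCC1=CS(=O)(=O)c2ccccc2C1=O` — 99.5%
compound 3 `O=C1C(CO)=CS(=O)(=O)c2ccccc21` — 99.3%

All three were tested in a functional assay on the whole organism for inhibition, with Mus musculus as the target, at a dose of 10 mg/kg; on this read-out higher numbers stand for more inhibition at the one dose given (going by the name of the read-out) and lower numbers for less inhibition. Compound 3 gives 99.3%, the second highest of the three numbers; compound 2 sits nearest, with a number 0.2 percentage points lower from compound 2 to compound 3 (within the scatter), and compound 1 furthest, with a number 6.9 percentage points higher from compound 1 to compound 3 (within the scatter). Compound 4 `CCNC(=O)OCC1=CS(=O)(=O)c2ccccc2C1=O` has not been measured. It differs from compound 3 by ethylcarbamoyl in place of hydrogen on an oxygen on a saturated carbon.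

Among the compounds with values here, two measured steps bear on this change, both at the same oxygen on a saturated carbon: a number 0.2 percentage points lower from compound 2 to compound 3 (within the scatter) and a number 7.1 percentage points higher from compound 1 to compound 2 (within the scatter). Neither exceeds the scatter, so within this set the identity of the group on that oxygen has made no difference that can be told apart from repeat measurement. Compound 4 is therefore expected to show no step beyond the scatter, with a number 3.3 percentage points lower from compound 3 to compound 4 (within the scatter) as the estimated change. The estimate for compound 4 in this assay is 96%, with a range from 85% to 100%.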

Compound 4, a percentage reported as inhibition, in the whole organism at one dose (the size of the read-out at that dose, not a potency): 99.3%
The estimate for compound 4 lay 3.3 percentage points below the measured number; measured number inside the range.
By their numbers in this assay, from the lowest: compounds 1, 3, 4 and 2 (each within the scatter of the next).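

In this assay, the step of no change at the digits printed from compound 3 to compound 4 (within the scatter) extends the earlier picture to a group of 5 heavy atoms that includes a nitrogen, and this ethylcarbamoyl group cannot be told apart from hydroxy. The comparison with the acetyl ester, where ethylamino replaces methyl on a carbonyl carbon, gives a number 0.2 percentage points lower from compound 2 to compound 4 (within the scatter), while the comparison with the ethyl ether gives a number 6.9 percentage points higher from compound 1 to compound 4 (within the scatter), so all four groups on this oxygen now lie within the scatter of one another. Nothing measured here bears on what lies behind this result.

From the compounds shown here alone, because the read-out comes from a single dose, it remains open whether these compounds would separate at a lower dose. Also open, going by these compounds, is whether a longer chain or a carboxylic acid in place of the carbamate's ethyl would stay within the scatter.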